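Switching the carbonyl substituent on the shared core

The source may report more compounds than this note shows. Statements on the series, on what has been measured and on what is new or still open speak of the compounds shown alone.

Compound 1 `O=C(Nc1ccc(F)cc1)N[C@@H]1C2CCN(CC2)[C@@H]1Cc1cccnc1` carries a (4-fluorophenyl)amino group on the carbonyl carbon. In an assay on a protein complex for binding affinity to Neuronal acetylcholine receptor; alpha4/beta2 (Homo sapiens) (a lower number here means a stronger inhibitor, a higher number a weaker inhibitor), compound 1 gives only a limit, > 10000 nM. Compound 2 `O=C(Nc1ccc(Oc2ccccc2)cc1)N[C@@H]1C2CCN(CC2)[C@@H]1Cc1cccnc1` likewise gives only a limit in this assay, > 10000 nM. Compound 3 `O=C(Nc1ccc(-c2ccccc2)cc1)N[C@@H]1C2CCN(CC2)[C@@H]1Cc1cccnc1` also gives only a limit, > 10000 nM. The steps a step that the two limits leave unreadable from compound 1 to compound 2, a step that the two limits leave unreadable from compound 1 to compound 3 and a step that the two limits leave unreadable from compound 2 to compound 3 therefore cannot be read, since all three values sit at the limit of > 10000 nM in this assay, at which 3 of the 3 values shown sit. Compound 1 thus stands at that limit with no number of its own.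

Compound 4 `Cn1cccc1C(=O)N[C@@H]1C2CCN(CC2)[C@@H]1Cc1cccnc1` differs from compound 1 by 1-methyl-1H-pyrrol-2-yl in place of (4-fluorophenyl)amino on a carbonyl carbon. Among the compounds with values here, none of the measured steps touches the carbonyl carbon; they vary only the substituent on the aromatic ring of the (4-fluorophenyl)amino group, and each is unreadable. The measured compounds give no direction for this change, only that three variations of that aromatic group left every value at the limit. Compound 4 is expected to remain weak, with an estimated step of an at least 1.2-fold lower number from compound 1 to compound 4 (0.09 log units; that floor lies within the scatter). The estimate for compound 4 is 8000 nM, with an expected range from 500 nM to 30000 nM, and a reading that is again only a limit is considered the more likely outcome.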

Compound 4, inhibition constant: > 10000 nM
Compound 4: no number, only a limit; the forecaster's own chance of this, stated with the estimate: 60%; middle value at least 1.2-fold (0.09 log units) from the limit.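

Compound 4 gives only a limit in this assay, > 10000 nM, so the step from compound 1 to compound 4 cannot be read, and the series stays without a readable step: the limit of > 10000 nM in this assay, at which 4 of the 4 values shown sit.

The compounds shown leave open how the 1-methyl-1H-pyrrol-2-yl and (4-fluorophenyl)amino groups on the carbonyl carbon compare, and whether any substituent there gives a measurable number.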